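A few compounds are considered here, and "the series" means these few. Any claim that something is new, unique, unknown or untested is made for them only; others in the source may bear on it.

In a functional assay on HeLa cells (Homo sapiens) for inhibition, read by sulforhodamine B assay (on this read-out lower numbers stand for stronger inhibition and higher numbers for weaker inhibition), compound 1 `CCOc1ccc(NC2=CC(=O)c3nc4n(c3C2=O)[C@H]2OC[C@@H](O)[C@H]2OC4)cc1` gives 3110 nM and compound 2 `CCOc1ccccc1NC1=CC(=O)c2nc3n(c2C1=O)[C@H]1OC[C@@H](O)[C@H]1OC3` gives 6040 nM. Among the compounds with values here, these are the only two numbers so far, and they cannot be told apart: the one measured step, 2-ethoxyphenyl in place of 4-ethoxyphenyl on an amine nitrogen, is a 1.9-fold higher number from compound 1 to compound 2 (0.29 log units; within the scatter). Compound 3 `Cc1ccc(NC2=CC(=O)c3nc4n(c3C2=O)[C@H]2OC[C@@H](O)[C@H]2OC4)cc1` has not yet been measured. It carries 4-methylphenyl in place of 2-ethoxyphenyl on an amine nitrogen, (4-methylphenyl in place of 2-ethoxyphenyl on an amine nitrogen). Within the data shown here, the measured step bears on this change only in part, since it shows the same place on the amine nitrogen but a different pair of groups, and no compound with 4-methylphenyl has a number yet. The size expected from this limited guide is small, with no shift beyond the scatter, and the estimated step is a 1.5-fold lower number from compound 2 to compound 3 (0.18 log units; within the scatter). For compound 3 the expected value is 4000 nM, with an estimated range of 1500 nM to 10000 nM.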

Compound 3, half-maximal inhibitory concentration: 3860 nM
The estimate for compound 3 lay 1.0-fold (0.02 log units) above the measured number, and the stated range covers the measured number.
By their numbers in this assay, from the lowest: compounds 1, 3 and 2 (each within the scatter of the next).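

In this assay, the step with 4-methylphenyl in place of 2-ethoxyphenyl on the amine nitrogen is a 1.6-fold lower number from compound 2 to compound 3 (0.19 log units; within the scatter), and the step with methyl in place of ethoxy on an aromatic carbon is a 1.2-fold higher number from compound 1 to compound 3 (0.09 log units; within the scatter). Compound 3 therefore adds a third aryl group at this place, and its number cannot be told apart from that of compound 1 or compound 2, so exchanging the ethoxy group for methyl, which removes the oxygen of the group, brings no change beyond the scatter. No measurement is at hand that would explain these numbers. On these data alone, whether an unsubstituted phenyl, a carboxylic acid or an amine on this aryl ring would move the number beyond the scatter stays open. So does the effect of replacing the aryl group on this nitrogen with a plain alkyl chain.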